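Dichlorobenzyl for cyanobenzyl on a sulfur-linked arm

The source may report more compounds than this note shows. Statements on the series, on what has been measured and on what is new or still open speak of the compounds shown alone.

Compound 1 `Cn1cc(SCc2nnc(S)n2-c2c(Cl)cccc2Cl)c2ccccc21` gives > 100000 nM in a toxicity assay on HEK-293T cells (Homo sapiens) for cytotoxicity, read by CCK-8 assay, with a stated time of 48 h (a lower number here means that less compound is tolerated, a higher number that more compound is tolerated), a limit of that assay.
Compound 2 `Cn1cc(SCc2nnc(SCc3ccccc3C#N)n2-c2c(Cl)cccc2Cl)c2ccccc21` gives 78600 nM in this assay.
Compound 3 `Cn1cc(SCc2nnc(SCc3cccc(Cl)c3Cl)n2-c2c(Cl)cccc2Cl)c2ccccc21` gives > 100000 nM in this assay, again a limit.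

Within the data shown here, compound 2 therefore stands as the only true number in the set, the other two sitting at the limit of > 100000 nM in this assay, at which 2 of the 3 values shown sit. Compound 4 `Cn1cc(SCc2nnc(SCc3ccc(Cl)cc3Cl)n2-c2c(Cl)cccc2Cl)c2ccccc21` differs from compound 2 by 2,4-dichlorophenyl in place of 2-cyanophenyl on a saturated chain carbon bound to a sulfur. The nearest measured step is an at least 1.2-fold higher number from compound 2 to compound 3 (0.10 log units; that floor lies within the scatter), a change that the scatter does not separate; an at least 1.2-fold lower number from compound 1 to compound 2 (0.10 log units; that floor lies within the scatter) is of the same order, and a step that the two limits leave unreadable from compound 1 to compound 3 cannot be sized. For compound 4 a step of a 1.3-fold higher number from compound 2 to compound 4 (0.10 log units; within the scatter) is expected, in this assay, with a fair chance that only a limit is reported. Compound 4 is estimated at 100000 nM, between 55000 nM and 180000 nM.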

Compound 4, half-maximal cytotoxic concentration: > 100000 nM
Compound 4 was reported as a limit; the forecaster's own chance of this, stated with the estimate: 50%; the middle value sits exactly at the limit.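

Among these compounds, with 2,4-dichlorobenzyl on the sulfur, a second dichlorobenzyl pattern at this position also ends in a limit in this assay, leaving compound 2 as the only true number: the limit of > 100000 nM in this assay, at which 3 of the 4 values shown sit. Replacing 2-cyanobenzyl with 2,4-dichlorobenzyl gives an at least 1.2-fold higher number from compound 2 to compound 4 (0.10 log units; that floor lies within the scatter), so this change is not separated from the scatter. Steps among compound 1, compound 3 and compound 4 cannot be read.

Any order among these three remains open. Also open, going by these compounds, is whether an amine or a carboxylic acid on the benzyl group, or a longer chain on the sulfur, would give a number clearly apart from compound 2.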